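The source may report more compounds than this note shows. Statements on the series, on what has been measured and on what is new or still open speak of the compounds shown alone.

Measured compounds in a functional assay on BGC-823 cells (Homo sapiens) for antiproliferative activity, read by MTT assay, tested at 1 uM; on this read-out lower numbers stand for a weaker effect and higher numbers for a stronger effect at the one concentration tested:
- compound 1, `COc1cc(C(=O)N/N=C/c2ccccc2C(F)(F)F)cc(OC)c1OC`: 22.1%
- compound 2, `COc1cc(C(=O)N/N=C/c2cccc(F)c2)cc(OC)c1OC`: 13.6%
- compound 3, `COc1ccc(C2OC(c3cc(OC)c(OC)c(OC)c3)=NN2C(C)=O)c(OC)c1`: 6.3%

Compound 3 has the lowest of the three numbers in this assay. Its gap to compound 2 is within the usual scatter, so the two cannot be placed in order; its gap to compound 1 lies beyond the scatter, and compound 1 therefore shows the stronger effect of that pair. Compound 1 and compound 2 share an open hydrazone arrangement, whereas compound 3 carries the ring-closed core with an acetyl group.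

Compound 4, `COc1cc(C2=NN(C(C)=O)C(c3cccc(F)c3)O2)cc(OC)c1OC`, keeps the core of compound 3 and differs from it in one place: 3-fluorophenyl in place of 2,4-dimethoxyphenyl on a saturated ring carbon. The exchange sits on a saturated ring carbon of a five-membered non-aromatic ring with 2 nitrogen and 1 oxygen.

Within the data shown here, no measured step separates two compounds that differ in a single place, so the size of this step has no direct precedent. The 3-fluorophenyl group is present in compound 2, which gives 13.6% in this assay, a number within the scatter of compound 3. The step of a number 2.7 percentage points higher from compound 3 to compound 4 (within the scatter) is estimated to stay within the scatter, with no direction that can be trusted. Compound 4 is expected to give 9% in this assay, with a range from 0% to 24%.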

Compound 4, a percentage reported as inhibition, at one concentration (the size of the read-out at that concentration, not a potency): 14.7%
Compound 4: the middle estimate sits 5.7 percentage points below what was measured, within the range that was stated.
By their numbers in this assay, from the lowest: compounds 3, 2, 4 and 1 (each within the scatter of the next, the first and the last beyond it).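

In this assay, the series now has its first step with a single change, a number 8.4 percentage points higher from compound 3 to compound 4 (within the scatter) on the saturated ring carbon next to the ring oxygen, and this step stays within the scatter. At this position, 3-fluorophenyl in place of the larger 2,4-dimethoxyphenyl, which also removes both hydrogen-bond acceptors of the group, gives no change that can be told from the scatter. No available evidence bears on this result.

The compounds shown leave open whether this carbon tolerates anything other than a substituted phenyl group, such as a primary amine, a carboxylic acid or a longer alkyl chain. They also leave open how the acetyl group on the ring nitrogen contributes, as no pair shown changes it alone.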